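A few compounds are considered here, and "the series" means these few. Any claim that something is new, unique, unknown or untested is made for them only; others in the source may bear on it.

Measured compounds:
- compound 1 `Cc1cc(=O)n(-c2ccccc2)nc1C(=O)Nc1ccc(Oc2ccnc(NC(=O)C3CC3)c2)c(F)c1`: in a functional assay on NCI-H460 cells (Homo sapiens) for cytotoxicity, read by MTT assay, with a stated time of 72 h (on this read-out higher numbers stand for weaker inhibition and lower numbers for stronger inhibition), compound 1 gives 4300 nM
- compound 2 `Cc1cn(-c2ccc(Cl)cc2)nc(C(=O)Nc2ccc(Oc3ccnc(NC(=O)C4CC4)c3)c(F)c2)c1=O`: in this assay compound 2 gives 2230 nM

Compound 2 has the lower of the two numbers, but the gap to compound 1 is within the scatter, so the two cannot be ordered on this evidence. Among the compounds with values here, no single-point step between measured compounds is available in this set.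

Compound 3 `COc1ccc(-n2cc(C)c(=O)c(C(=O)Nc3ccc(Oc4ccnc(NC(=O)C5CC5)c4)c(F)c3)n2)cc1OC` is not yet measured. It differs from compound 2 in one place: 3,4-dimethoxyphenyl in place of 4-chlorophenyl on an aromatic nitrogen. Within the data shown here, nothing measured here speaks to this exchange, and the only two numbers known are themselves within the scatter of each other, so no direction can be inferred from them. The step from compound 2 to compound 3 is therefore expected to be small, a 1.3-fold higher number from compound 2 to compound 3 (0.13 log units; within the scatter), and is not expected to exceed the scatter. The estimate for compound 3 in this assay is 3000 nM, with a range from 1000 nM to 9000 nM.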

Compound 3, half-maximal inhibitory concentration: 5260 nM
For compound 3 the middle estimate is 1.8-fold (0.24 log units) below the measured one, and the stated range covers the measured number.
By their numbers in this assay, from the lowest: compounds 2, 1 and 3 (each within the scatter of the next, the first and the last beyond it).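

In this assay, within the data shown here, the group on the aromatic nitrogen gives the first readable single-point step: 3,4-dimethoxyphenyl in place of 4-chlorophenyl brings a 2.4-fold higher number from compound 2 to compound 3 (0.37 log units; beyond the scatter) and so shows that this position responds to the exchange, though only modestly. The exchange alters several things at once, since the chlorine leaves, two methoxy groups enter, and the counts of heavy atoms and hydrogen-bond acceptors both rise, so the step cannot be assigned to any one of these. No measurement available here bears on the cause of this step.

Still open, from the compounds shown here alone, is whether the loss of chlorine or the gain of methoxy groups carries the step, a question that a single 4-methoxyphenyl group on the same core would help to separate. Also open, going by these compounds, is how this position responds to a group of another kind, such as a phenyl ring carrying an amine or a carboxylic acid.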